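The source may hold more compounds than are shown below. What is called first, only, known or untested is meant among the compounds shown, and "the series" means these compounds.

Measured in a functional assay on T98G cells (Homo sapiens) for cytotoxicity, read by MTT assay, with a stated time of 48 h; on this read-out higher numbers stand for weaker inhibition and lower numbers for stronger inhibition:
compound 1 `C/C(=N/NC(=S)Nc1ccc([N+](=O)[O-])cc1)c1ccccn1`: 140 nM
compound 2 `CC(=NNC(=S)Nc1ccc(F)cc1)c1ccccn1`: 17 nM

Compound 2 has the lower of the two numbers, and its gap to compound 1 lies beyond the scatter. Compound 3 `CC(=NNC(=S)Nc1ccc([N+](=O)[O-])cc1)c1ccccn1` has not yet been measured. It differs from compound 2 by nitro in place of fluoro on an aromatic carbon, para to a large group: nitro in place of fluoro on an aromatic carbon. Within the data shown here, no measured single-place step is available as a guide. Compound 1 also carries a nitro group and gives 140 nM, so a rise beyond the scatter, toward weaker inhibition, is expected in this assay. The expected change is an 8.2-fold higher number from compound 2 to compound 3 (0.92 log units; beyond the scatter). Compound 3 is estimated at 140 nM, with an expected range of 70 nM to 280 nM.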

Compound 3, half-maximal inhibitory concentration: 140 nM
Beside the measured number, compound 3's estimate shows no gap at the digits printed; the measured number falls inside the stated range.
By their numbers in this assay, from the lowest: compound 2; then compounds 1 and 3 (each within the scatter of the next).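

In this assay, nitro in place of fluoro on an aromatic carbon, para to a large group, gives an 8.2-fold higher number from compound 2 to compound 3 (0.92 log units; beyond the scatter), the first single-place step read at this position. Drawing the double bond with or without a configuration gives no change at the digits printed from compound 1 to compound 3 (within the scatter), so the nitro result holds across both drawings. The only difference within that pair is one of depiction: the fact that one of compounds 1 and 3 is drawn with a defined configuration and the other without, at the place where they differ

With only fluoro and nitro shown at this position, the step gives one comparison, not a trend. Where an amine, a methoxy group or a carboxylic acid would fall there remains open.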